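Removing one methyl from the core of compound 1

This account rests on a few compounds, and the source may have more. Where it says the series, first, only, none or still open, it means among the compounds named here.

Compound 1 `COc1cccc(/C=C/C(=O)c2c(OC)cc(OC)cc2OC)c1` is the parent here. In a functional assay on NCI-H727 cells (Homo sapiens) for cytotoxicity, with a stated time of 48 h (a lower number here means a stronger inhibitor, a higher number a weaker inhibitor), compound 1 gives 8200 nM. Among the three measured compounds it stands second highest: compound 2 `COc1cc(OC)c(C(=O)/C=C/c2ccc(Cl)cc2)c(OC)c1` gives 6000 nM, compound 3 `COc1cc(OC)c(C(=O)/C=C/c2ccc(Br)cc2)c(OC)c1` gives 11300 nM, and the steps of a 1.4-fold lower number from compound 1 to compound 2 (0.14 log units; within the scatter), a 1.4-fold higher number from compound 1 to compound 3 (0.14 log units; within the scatter) and a 1.9-fold higher number from compound 2 to compound 3 (0.27 log units; within the scatter) all stay within the scatter, so the three numbers cannot be told apart.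

Compound 4 `COc1cccc(/C=C/C(=O)c2c(O)cc(OC)cc2OC)c1` differs from compound 1 by hydrogen in place of methyl on an oxygen on an aromatic ring. Among the compounds with values here, none of the measured steps touches this position: each of them changes the 3-methoxyphenyl or the halogen on it, while the oxygen on the aromatic ring of the core is untouched in all three. The data therefore give no direct guide, and the measured changes elsewhere all proved too small to resolve.

With that in mind, the number for compound 4 is expected to stay close to compound 1, the estimated step being a 1.3-fold lower number from compound 1 to compound 4 (0.10 log units; within the scatter). Compound 4 is estimated at 6500 nM, with a range from 1500 nM to 25000 nM.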

Compound 4, half-maximal inhibitory concentration: 14800 nM
The estimate for compound 4 lay 2.3-fold (0.36 log units) below the measured number, within the range that was stated.
By their numbers in this assay, from the lowest: compounds 2, 1, 3 and 4 (each within the scatter of the next, the first and the last beyond it).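

Within the data shown here, compound 4 gives the first reading of a change on the core itself, since the earlier steps all lay in the 3-methoxyphenyl or the halogen on that ring. In this assay the change from methoxy to hydroxy on the aromatic ring gives a 1.8-fold higher number from compound 1 to compound 4 (0.26 log units; within the scatter) and so shows that this methyl can be exchanged for hydrogen without a difference the assay can resolve. Nothing available here explains this result or gives any measured property of the two groups.

The compounds shown leave open whether an amine in place of the hydroxy, or a longer chain such as ethoxy on this oxygen, would also stay within the scatter. They also leave open whether the same exchange would read alike with the 4-chlorophenyl of compound 2 or the 4-bromophenyl of compound 3 in place of the 3-methoxyphenyl.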